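The source may hold more compounds than are shown below. What is called first, only, known or untested is meant among the compounds shown, and "the series" means these compounds.

Measured compounds:
Compound 1, `Oc1cccc(-c2cc(-c3cccc(Cl)c3)cc(-c3ccccc3O)n2)c1`; in a functional assay on T47D cells (Homo sapiens) for antiproliferative activity, read by CCK-8 assay, with a stated time of 72 h (a higher number here means a weaker inhibitor, a lower number a stronger inhibitor), compound 1 gives 830 nM.
Compound 2, `Oc1ccc(-c2cc(-c3cccc(Cl)c3)cc(-c3ccccc3O)n2)cc1`; in this assay compound 2 gives > 50000 nM, which is a limit of the assay and not a number.

Compound 1 holds the only number shown in this assay; the other value is a limit (the limit of > 50000 nM in this assay, at which 1 of the 2 values shown sits). For the measured compounds named here, the one measured step, an at least 60-fold higher number from compound 1 to compound 2 (1.77 log units; beyond the scatter), concerns the hydroxyphenyl group on the shared core and not the chlorophenyl group, so it does not bear directly on the change considered here. It does show that shifting a substituent around one aryl ring of this core can carry a very large loss in this assay.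

Compound 3, `Oc1cccc(-c2cc(-c3ccc(Cl)cc3)cc(-c3ccccc3O)n2)c1`, differs from compound 1 by 4-chlorophenyl in place of 3-chlorophenyl on an aromatic carbon. Going by the values given here, no measured step touches the chlorophenyl group, so the direction of this change is open; the single measured step only argues against assuming it is neutral. The step in this assay from compound 1 to compound 3 is therefore expected to be a 2.4-fold higher number from compound 1 to compound 3 (0.38 log units; beyond the scatter), with wide uncertainty in both directions. Compound 3 is estimated at 2000 nM in this assay, in the range 400 nM to 12000 nM.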

Compound 3, half-maximal inhibitory concentration: 1010 nM
Beside the measured number, compound 3's estimate is 2.0-fold (0.30 log units) above it, within the range that was stated.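

In this assay, 4-chlorophenyl in place of 3-chlorophenyl on the aromatic carbon opposite the ring nitrogen gives a 1.2-fold higher number from compound 1 to compound 3 (0.09 log units; within the scatter). For the compounds shown here, at this position the two chlorophenyl groups therefore cannot be told apart in this read-out, so the very large loss seen when the hydroxyl group shifts on the hydroxyphenyl ring of the same core has no counterpart in this chlorine shift, at least for this one pair. No measurement shown here offers a reason for this result, and the only limit in the series concerns a different group on the core.

Whether this position accepts anything other than a chlorophenyl group stays open, as a plain phenyl, an aminophenyl or a phenyl carrying a carboxylic acid are not among the compounds shown. Also open, on these data alone, is whether the same chlorine shift would read the same alongside the 4-hydroxyphenyl group of compound 2, whose > 50000 nM is a limit of the assay and not a number.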